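Adding a Butyl Group to Compound 3

The compounds below may be only part of what the source reports. "The series", "measured", "known", "first", "only" and "open" are said of these compounds alone.

In a functional assay on A375M cells (Homo sapiens) for cytotoxicity, read by MTT assay, with a stated time of 4 days (on this read-out lower numbers stand for stronger inhibition and higher numbers for weaker inhibition), compound 1 (`C=C1C(=O)OC(CCCCCCCCCCCCC)C1CC`) gives 4100 nM, compound 2 (`C=C1CC(CCCC)OC1=O`) gives 17300 nM, and compound 3 (`C=C1CC(c2ccccc2)OC1=O`) gives 6700 nM. Compound 3 therefore lies within the usual scatter of compound 1 and clearly lower than compound 2. Compound 4 (`C=C1C(=O)OC(c2ccccc2)C1CCCC`) differs from compound 3 in one place: butyl in place of hydrogen on a saturated ring carbon. Within the data shown here, no measured pair shows this change alone. Only compound 1 already carries a chain on that ring carbon, and compound 1, at 4100 nM, is within the scatter of compound 3, so only a small change is expected. In this assay, the expected step of a 1.5-fold lower number from compound 3 to compound 4 (0.17 log units; within the scatter) stays within the scatter. Compound 4 is estimated at 4500 nM, with a range of 1800 nM to 11000 nM.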

Compound 4, half-maximal inhibitory concentration: 7800 nM
For compound 4 the middle estimate is 1.7-fold (0.24 log units) below the measured one, and the stated range covers the measured number.
By their numbers in this assay, from the lowest: compounds 1, 3 and 4 (each within the scatter of the next); then compound 2.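

In this assay, butyl in place of hydrogen on this saturated ring carbon gives a 1.2-fold higher number from compound 3 to compound 4 (0.07 log units; within the scatter). Among these compounds, this is the first pair to show this change alone, and it shows that this ring carbon can carry a butyl group without a difference that stands out from repeat scatter. Nothing available offers an explanation for this result. This single pair cannot show whether the same holds for other groups at this position. An amine, a carboxylic acid or a longer chain on this ring carbon remains an open case.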